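Swapping the aryl end of a chalcone-type urea

This account rests on a few compounds, and the source may have more. Where it says the series, first, only, none or still open, it means among the compounds named here.

Three compounds share one core and differ only in the ring at the far end of the double-bonded chain. Compound 1 `Cc1ccc(S(=O)(=O)NC(=O)Nc2ccccc2C(=O)/C=C/c2ccc(N(C)C)cc2)cc1` gives 38.1 ug/mL in an ADME assay on the whole organism for cytotoxicity, with Artemia salina as the target, with a stated time of 24 h; on this read-out lower numbers stand for an effect already at smaller amounts and higher numbers for an effect only at larger amounts of compound. Compound 2 `Cc1ccc(S(=O)(=O)NC(=O)Nc2ccccc2C(=O)/C=C/c2cccc(O)c2)cc1` gives 39.3 ug/mL in the same test, and compound 3 `Cc1ccc(S(=O)(=O)NC(=O)Nc2ccccc2C(=O)/C=C/c2cccc([N+](=O)[O-])c2)cc1` gives 44.5 ug/mL. Going by the values given here, the three numbers sit close together: the steps of a 1.0-fold higher number from compound 1 to compound 2 (0.01 log units; within the scatter), a 1.2-fold higher number from compound 1 to compound 3 (0.07 log units; within the scatter) and a 1.1-fold higher number from compound 2 to compound 3 (0.05 log units; within the scatter) all fall inside the usual scatter, so no compound can be set apart from the others on this read-out.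

Compound 4 `Cc1ccc(S(=O)(=O)NC(=O)Nc2ccccc2C(=O)/C=C/c2cccnc2)cc1` is not yet measured. It differs from compound 3 in this way: pyridin-3-yl in place of 3-nitrophenyl on a double-bonded chain carbon bound to a double-bonded chain carbon. The three measured steps are all changes of the same ring at the same place, and none of them moved the number beyond the scatter. For compound 4 the step of a 1.1-fold lower number from compound 3 to compound 4 (0.04 log units; within the scatter) is therefore expected to stay within the scatter as well. Compound 4 is estimated at 41 ug/mL, with a range from 20 ug/mL to 85 ug/mL.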

Compound 4, concentration for half-maximal effect: 14.1 ug/mL
The estimate for compound 4 lay 2.9-fold (0.46 log units) above the measured number; the whole stated range lies above it.
By their numbers in this assay, from the lowest: compound 4; then compounds 1, 2 and 3 (each within the scatter of the next).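

The ring on this double-bonded chain carbon can move the number after all: in this assay, the change to pyridin-3-yl gives a 3.2-fold lower number from compound 3 to compound 4 (0.50 log units; beyond the scatter), a 2.8-fold lower number from compound 2 to compound 4 (0.45 log units; beyond the scatter) and a 2.7-fold lower number from compound 1 to compound 4 (0.43 log units; beyond the scatter). Compound 4 is the only one of the four with a hetero atom in this ring, while compounds 1, 2 and 3 carry rings of carbon only and stay within the scatter of one another despite their different groups. The change does more than exchange one group on the ring. It alters the ring itself and also leaves the ring without the nitro, hydroxy or dimethylamino group.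

Nothing at hand gives a measured reason for the lower number. A plain phenyl or a pyridin-4-yl at this place would help show whether the ring nitrogen, its location or the missing group matters.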